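Shortening the alkyl side chain of compound 1

The source may hold more compounds than are shown below. What is called first, only, known or untested is meant among the compounds shown, and "the series" means these compounds.

compound 1 `CCCCCCc1cn([C@H]2C[C@H](O)[C@@H](CO)O2)c(=O)[nH]c1=O`: 195 ug/mL
compound 2 `CCCCCCc1cn([C@H]2C[C@@H]3OP(=O)(O)OC[C@H]3O2)c(=O)[nH]c1=O`: > 500 ug/mL, a limit
compound 3 `CCCCCc1cn([C@H]2C[C@@H]3OP(=O)(O)OC[C@H]3O2)c(=O)[nH]c1=O`: > 500 ug/mL, a limit

Within the data shown here, in a functional assay on L1210 cells (Mus musculus) (on this read-out higher numbers stand for weaker inhibition and lower numbers for stronger inhibition), compound 1 gives 195 ug/mL, the only number in the set. The other two values are limits. Compound 2 reaches only the limit > 500 ug/mL in this assay. Compound 3 likewise reaches only the limit > 500 ug/mL. The step that the two limits leave unreadable from compound 2 to compound 3 stays unreadable because both ends sit at the limit of > 500 ug/mL in this assay, at which 2 of the 3 values shown sit.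

Compound 4 `CCCc1cn([C@H]2C[C@H](O)[C@@H](CO)O2)c(=O)[nH]c1=O` differs from compound 1 by hydrogen in place of propyl on a saturated chain carbon, three bonds along the chain from an aromatic carbon. Among the measured compounds shown here, no measured step covers a change on this chain at this length, so nothing here fixes its size or direction. Compound 4 is therefore expected to stay near compound 1, at an estimated 300 ug/mL, between 120 ug/mL and 800 ug/mL. That estimate means an expected step of a 1.5-fold higher number from compound 1 to compound 4 (0.19 log units; within the scatter), within the usual scatter.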

Compound 4, concentration for 50% inhibition: > 500 ug/mL
Compound 4 gave a limit, no number; the forecaster's own chance of this, stated with the estimate: 25%; middle value at least 1.6-fold (0.22 log units) away from the limit.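

Among these compounds, on the core of compound 1, chain length does register in this assay: going from hexyl to propyl gives an at least 2.5-fold higher number from compound 1 to compound 4 (0.40 log units; beyond the scatter), the first readable step on this chain, since the step from compound 2 to compound 3 cannot be read. Compound 4 gives only a limit, so the full size of the step stays unknown: the limit of > 500 ug/mL in this assay, at which 3 of the 4 values shown sit.

Open, going by these compounds, is whether butyl or pentyl on this core keeps a readable value. Also open, on these data alone, is whether a longer chain such as octyl lowers the number below that of compound 1.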